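A few compounds are considered here, and "the series" means these few. Any claim that something is new, unique, unknown or untested is made for them only; others in the source may bear on it.

Values in a functional assay on HCT-116 cells (Homo sapiens) for inhibition, read by MTT assay, with a stated time of 96 h (on this read-out lower numbers stand for stronger inhibition of growth and higher numbers for weaker inhibition of growth), are as follows
compound 1 `O=C(OCc1ccccc1)SCCCCCCNC(=O)c1cc(-c2ccncc2)n[nH]1` gives 18200 nM as a number
compound 2 `O=C(NCCCCCCS)c1cc(-c2c[nH]c3ccccc23)n[nH]1` gives > 50000 nM as a limit
compound 3 `O=C(CCCCCCS)Nc1ccccc1` gives > 50000 nM as a limit

Compound 1 is the only one of the three with a number, the other two values being limits. Compound 4 `CC(=O)SCCCCCCNC(=O)c1cc(-c2ccncc2)n[nH]1` differs from compound 1 by methyl in place of benzyloxy on a carbonyl carbon with methyl in place of benzyloxy on a carbonyl carbon. Among the compounds with values here, no measured step covers this change, so the expectation rests on compound 1 at 18200 nM alone. In this assay the expected step of a 1.1-fold lower number from compound 1 to compound 4 (0.06 log units; within the scatter) is small and stays within the scatter, with no direction favoured. For compound 4 the estimated value is 16000 nM within an expected range from 5000 nM to 45000 nM in the same read-out.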

Compound 4, concentration for 50% growth inhibition: 41100 nM
Estimate against measurement, compound 4: 2.6-fold (0.41 log units) below; the measured number falls inside the stated range.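

In this assay, within the data shown here, the change from benzyloxycarbonyl to acetyl on the sulfur gives the first measured step, a 2.3-fold higher number from compound 1 to compound 4 (0.35 log units; beyond the scatter), so this position does affect growth inhibition, with benzyloxy giving the lower number. Compound 4 stands close to the limit of the read-out, which leaves little room to resolve any further weakening at this position: the limit of > 50000 nM in this assay, at which 2 of the 4 values shown sit.

With only benzyloxy and methyl shown here, it remains open whether the aromatic ring or the oxygen accounts for the step. As far as these compounds go, how a dimethylamino group or a longer chain such as hexyl would read on the same carbonyl carbon also remains open.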